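Replacing an ortho bromo by nitro in a hydrazone series

The source may hold more compounds than are shown below. What is called first, only, known or untested is meant among the compounds shown, and "the series" means these compounds.

Three hydrazones built on the shared core of compound 1 `O=C(COc1cccc2ccccc12)N/N=C/c1ccc(Cl)cc1` have been tested in an ADME assay on MT4 cells (Homo sapiens) for cytotoxicity, read by MTT assay, with a stated time of 4 days; on this read-out higher numbers stand for lower toxicity in this test and lower numbers for higher toxicity in this test. Compound 1 gives 87.6 ug/mL. Compound 2 `O=C(COc1cccc2ccccc12)N/N=C/c1ccccc1Br` gives 11.4 ug/mL, and compound 3 `O=C(COc1cccc2ccccc12)N/N=C/c1cccc(Br)c1` gives 87.4 ug/mL. On these numbers compound 2 stands lowest of the three: the step of a 7.7-fold lower number from compound 1 to compound 2 (0.89 log units; beyond the scatter) and the step of a 7.7-fold higher number from compound 2 to compound 3 (0.88 log units; beyond the scatter) are both beyond the scatter, whereas a 1.0-fold lower number from compound 1 to compound 3 (0.00 log units; within the scatter) is within it.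

Compound 4 `O=C(COc1cccc2ccccc12)N/N=C/c1ccccc1[N+](=O)[O-]` is not yet measured. It differs from compound 2 in one place: nitro in place of bromo on an aromatic carbon. Among the measured compounds shown here, both measured steps that touch compound 2, a 7.7-fold lower number from compound 1 to compound 2 (0.89 log units; beyond the scatter) and a 7.7-fold higher number from compound 2 to compound 3 (0.88 log units; beyond the scatter), move a halogen from one position of the phenyl ring to another; neither replaces the group itself, and no measured compound carries a nitro. For the measured compounds named here, they therefore show only that the compound with the group ortho to the large group gives the lowest number, and give no direct guide to the exchange of bromo for nitro. The expected step of a 2.2-fold higher number from compound 2 to compound 4 (0.34 log units; beyond the scatter) is thus uncertain, with a wide range. Compound 4 is estimated at 25 ug/mL, expected to fall between 7 ug/mL and 90 ug/mL.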

Compound 4, half-maximal cytotoxic concentration: 12.2 ug/mL
Beside the measured number, compound 4's estimate is 2.0-fold (0.31 log units) above it; the range from low to high includes it.
By their numbers in this assay, from the lowest: compounds 2 and 4 (each within the scatter of the next); then compounds 3 and 1 (each within the scatter of the next).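

In this assay, the exchange of bromo for nitro on an aromatic carbon ortho to a large group gives a 1.1-fold higher number from compound 2 to compound 4 (0.03 log units; within the scatter), so the two compounds cannot be told apart on this read-out. The earlier compounds shown here only compared halogen-bearing rings with the substituent in different places, and they left open whether the low number found with bromo belonged to bromo alone. This result shows that, at this position, the number is kept when bromo gives way to nitro, a group with more heavy atoms and with hydrogen-bond acceptors that bromo lacks, and no measurement at hand explains this match.

The compounds shown leave open whether a quite different group at this position, such as an amine or a carboxylic acid, would also keep the number there. They also leave open whether nitro, moved to the place that bromo holds in compound 3, would repeat the shift seen with bromo, a 7.7-fold higher number from compound 2 to compound 3 (0.88 log units; beyond the scatter).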